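A few compounds are considered here, and "the series" means these few. Any claim that something is new, unique, unknown or untested is made for them only; others in the source may bear on it.

In a functional assay on HL-60 cells (Homo sapiens) for antiproliferative activity, read by MTT assay, with a stated time of 72 h (on this read-out lower numbers stand for stronger inhibition and higher numbers for weaker inhibition), compound 2 `CN(C(=O)c1ccc(F)cc1)c1ccc2[nH]c(-c3n[nH]c4ccccc34)cc2n1` gives 1210 nM, the lower of the two numbers measured; compound 1 `CC(=O)N(C)c1ccc2[nH]c(-c3n[nH]c4ccccc34)cc2n1` gives 5110 nM. Among the compounds with values here, the only measured step, a 4.2-fold lower number from compound 1 to compound 2 (0.63 log units; beyond the scatter), puts an aryl on the carbonyl carbon. Compound 3 `Cc1ccc(S(=O)(=O)N(C)c2ccc3[nH]c(-c4n[nH]c5ccccc45)cc3n2)cc1` differs from compound 2 by (4-methylphenyl)sulfonyl in place of (4-fluorophenyl)carbonyl on a nitrogen on an aromatic ring. No measured step replaces a carbonyl by a sulfonyl; the one step shown bears on it only in that an aryl is kept. The step to compound 3 is expected to be a 1.7-fold higher number from compound 2 to compound 3 (0.22 log units; within the scatter), within the scatter. For compound 3 the estimate is 2000 nM, with a range from 600 nM to 7000 nM.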

Compound 3, half-maximal inhibitory concentration: 3030 nM
The estimate for compound 3 lay 1.5-fold (0.18 log units) below the measured number, and the stated range covers the measured number.
By their numbers in this assay, from the lowest: compound 2; then compounds 3 and 1 (each within the scatter of the next).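

In this assay there is a 2.5-fold higher number from compound 2 to compound 3 (0.40 log units; beyond the scatter) when (4-methylphenyl)sulfonyl replaces (4-fluorophenyl)carbonyl on this nitrogen, so an aryl at this place does not alone keep the number of compound 2. Replacing acetyl with (4-methylphenyl)sulfonyl gives a 1.7-fold lower number from compound 1 to compound 3 (0.23 log units; within the scatter) in the same assay. No evidence bears on the reason for these steps.

The step to compound 3 changes both the linking group and the aryl group, and (4-fluorophenyl)sulfonyl would separate the two. As far as these compounds go, how an amine or a longer chain would fare at this place remains open.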